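The source may hold more compounds than are shown below. What is called first, only, known or untested is meant among the compounds shown, and "the series" means these compounds.

The series rests on the core of compound 1 `COc1ccc(N2C(=O)N/C(=C\c3ccc(O)cc3)C2=O)cc1`, which carries a methoxy group. In a functional assay on NCI-H292 cells (Homo sapiens) for antiproliferative activity (on this read-out lower numbers stand for stronger inhibition and higher numbers for weaker inhibition), compound 1 gives > 200000 nM, and this value is a limit of the assay rather than a number. For the measured compounds named here, compound 2 `O=C1N/C(=C\c2ccc(O)cc2)C(=O)N1c1cccc(Br)c1` is the only other measured member of the set. In this assay compound 2 gives > 200000 nM, which is again a limit of the assay. Going by the values given here, compound 1 therefore stands at the limit of > 200000 nM in this assay, at which 2 of the 2 values shown sit, level with the one other measured compound, and no measured step between two compounds exists here. The unmeasured compound 3 `O=C(NCc1ccccc1)c1ccc(N2C(=O)N/C(=C\c3ccc(O)cc3)C2=O)cc1` differs from compound 1 in one place: benzylcarbamoyl in place of methoxy on an aromatic carbon. Among the compounds with values here, with no measured step to lean on, the step from compound 1 to compound 3 is expected to be an at least 1.3-fold lower number from compound 1 to compound 3 (0.12 log units; that floor lies within the scatter), an improvement that may or may not reach beyond the scatter. Compound 3 is estimated at 150000 nM, with a range from 30000 nM to 400000 nM, and it may well again be reported only as a limit.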

Compound 3, half-maximal inhibitory concentration: > 200000 nM
Compound 3: no number, only a limit; the forecaster's own chance of this, stated with the estimate: 55%; at least 1.3-fold (0.12 log units) between middle value and limit.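

Compound 3 likewise returns only a limit of the assay, so both it and compound 1 sit at a limit and the step between them cannot be read: the limit of > 200000 nM in this assay, at which 3 of the 3 values shown sit.

The compounds shown leave open whether any change on the shared core gives a readable number in this assay, and so what benzylcarbamoyl in place of methoxy does there.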